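Tetrazole substituent series in FAAH brain microsome inhibition

A few compounds are considered here, and "the series" means these few. Any claim that something is new, unique, unknown or untested is made for them only; others in the source may bear on it.

Measured compounds:
- compound 1, `CCCCCCCCc1ccc(OCC(=O)Cn2nnc(SC)n2)cc1`: 31 nM
- compound 2, `CCCCCCCCc1ccc(OCC(=O)Cn2nnc(-c3cccnc3)n2)cc1`: 23 nM

The two measured compounds share one core and differ only in the group on the aromatic carbon of the five-membered ring. In an assay on microsomes from brain for inhibition of Fatty-acid amide hydrolase 1 (Rattus norvegicus), read by fluorescence and HPLC, with a stated time of 60 min (on this read-out lower numbers stand for stronger inhibition and higher numbers for weaker inhibition), compound 1 gives 31 nM and compound 2 gives 23 nM. The step of a 1.3-fold lower number from compound 1 to compound 2 (0.13 log units; within the scatter) is within the scatter, so the two numbers are treated as equal; compound 2 has the lowest of the two numbers, but with only compound 1 as neighbour this does not mark it as stronger.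

Compound 3 is `CCCCCCCCc1ccc(OCC(=O)Cn2nnc(C(=O)O)n2)cc1`. It differs from compound 2 by carboxy in place of pyridin-3-yl on an aromatic carbon. For the measured compounds named here, no measured step covers an exchange of this kind; the single step in hand only shows that two different groups at this position give numbers within the scatter of each other. That step therefore gives no direction for compound 3, and a change beyond the scatter in either sense cannot be excluded.

On this basis compound 3 is expected at 80 nM in this assay, with a range of 20 nM to 400 nM, the estimated step being a 3.5-fold higher number from compound 2 to compound 3 (0.54 log units; beyond the scatter).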

Compound 3, half-maximal inhibitory concentration: 41 nM
Compound 3: middle estimate off by 2.0-fold (0.29 log units), on the high side, and the stated range covers the measured number.
By their numbers in this assay, from the lowest: compounds 2, 1 and 3 (each within the scatter of the next).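

In this assay the exchange of pyridin-3-yl for carboxy on the aromatic carbon of the five-membered ring gives a 1.8-fold higher number from compound 2 to compound 3 (0.25 log units; within the scatter) and the exchange of methylsulfanyl for carboxy gives a 1.3-fold higher number from compound 1 to compound 3 (0.12 log units; within the scatter). For the compounds shown here, the earlier pair covered only two groups, whereas all three pairs now lie within the scatter, so this position accepts carboxy without a readable change in the number, even though carboxy has no ring, has fewer heavy atoms than pyridin-3-yl and brings a hydrogen-bond donor that pyridin-3-yl lacks. No supporting data are available to explain why these three groups give numbers that count as equal.

The compounds shown leave open whether an amine, a methyl ester of the carboxylic acid or a longer chain on this same aromatic carbon would also stay within the scatter of these three, or would give the first step beyond it. They also leave open whether carboxy would remain equal to pyridin-3-yl and methylsulfanyl if the chain on the shared core were replaced by a shorter chain.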